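The compounds below may be only part of what the source reports. "The series", "measured", "known", "first", "only" and "open" are said of these compounds alone.

In a functional assay on PC-3 cells (Homo sapiens) for cytotoxicity, read by MTT assay, with a stated time of 48 h (on this read-out higher numbers stand for weaker inhibition and lower numbers for stronger inhibition), compound 1 `CCN(CC)CC(=O)N1N=C(C)CC1c1ccccc1O` gives 25900 nM.
In this assay compound 2 `CCC(=O)N1N=C(c2cc3ccccc3oc2=O)CC1c1ccccc1` gives 4370 nM.

Of these two measured compounds, compound 2 has the lower number, and its gap to compound 1 lies beyond the usual scatter of repeated measurements, so compound 2 is the stronger inhibitor of the pair. Going by the values given here, the two share no single point of difference, so no step between them can be singled out.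

Compound 3 `Cc1ccc(S(=O)(=O)N2N=C(c3cc4ccccc4oc3=O)CC2c2ccccc2)cc1` is drawn from compound 2 by one change: (4-methylphenyl)sulfonyl in place of propanoyl on an amine nitrogen in a ring. Among the compounds with values here, no measured pair shows what such an exchange on this core does in this assay, so any expectation rests on compound 2 alone. The step of a 1.2-fold lower number from compound 2 to compound 3 (0.10 log units; within the scatter) is estimated to stay within the scatter, with no confident direction. Compound 3 is therefore expected to give about 3500 nM in this assay, somewhere between 1000 nM and 12000 nM.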

Compound 3, half-maximal inhibitory concentration: 48600 nM
Estimate against measurement, compound 3: 14-fold (1.14 log units) below, and the stated range ends below it.
By their numbers in this assay, from the lowest: compound 2; then compounds 1 and 3 (each within the scatter of the next).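

On the shared core, the amine nitrogen in a ring does not accept every group equally. In this assay, placing (4-methylphenyl)sulfonyl there in place of propanoyl gives an 11-fold higher number from compound 2 to compound 3 (1.05 log units; beyond the scatter), so this one exchange is enough to weaken inhibition markedly. The entering group has 10 heavy atoms against 4 and adds a six-membered aromatic ring, but no measurement at hand says what lies behind the rise.

This single exchange swaps several features at once, so it cannot separate the sulfonyl group from the aromatic ring attached to it. The compounds shown leave open whether methanesulfonyl, which has a sulfonyl group but no aromatic ring, or benzoyl, which has an aromatic ring but no sulfonyl group, would behave more like compound 2 or compound 3 on this nitrogen, and how a longer chain such as butanoyl would fare.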